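Lengthening the Acyl Group on the Ring Nitrogen of Compound 2

The compounds below may be only part of what the source reports. "The series", "measured", "known", "first", "only" and "open" are said of these compounds alone.

Compound 2 `CC(=O)N1c2ccccc2CCC1C(=O)Nc1cc(C(F)(F)F)cc(C(F)(F)F)c1` carries a trifluoromethyl-substituted anilide on the shared core and an acetyl group on the ring nitrogen. In a functional assay on PC-3 cells (Homo sapiens) for cytotoxicity, read by sulforhodamine B assay, with a stated time of 72 h (a higher number here means a weaker inhibitor of growth, a lower number a stronger inhibitor of growth), compound 2 gives only a limit, > 70000 nM, and no number. That limit, (the limit of > 70000 nM in this assay, at which 1 of the 3 values shown sits), marks where compound 2 stands among the three values measured. For comparison, compound 1 `O=C(Nc1ccc(C(F)(F)F)cc1)C1CCc2ccccc2N1` gives 20300 nM in this assay, and compound 3 `COc1ccc(NC(=O)C2CCc3ccccc3N2)cc1` gives 56900 nM. Among the compounds with values here, the one measured step, a 2.8-fold higher number from compound 1 to compound 3 (0.45 log units; beyond the scatter), concerns the aryl substituent of the anilide and not the acyl group on the ring nitrogen.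

Compound 4 `CCC(=O)N1c2ccccc2CCC1C(=O)Nc1cc(C(F)(F)F)cc(C(F)(F)F)c1` differs from compound 2 by methyl in place of hydrogen on a saturated chain carbon bound to a carbonyl carbon, acetyl to propanoyl. Within the data shown here, no measured step touches this position, so compound 2 itself is the only guide, and it sits at the limit. Compound 4 is therefore expected to remain near that limit, a step that the limit leaves unreadable from compound 2 to compound 4 in this assay. The estimate for compound 4 is 80000 nM, within 30000 nM to 250000 nM.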

Compound 4, concentration for 50% growth inhibition: 8540 nM
For compound 4 the middle estimate is 9.4-fold (0.97 log units) above the measured one; measured number below the stated range.
By their numbers in this assay, from the lowest: compound 4; then compound 1; then compound 3. At a limit, above all of these: compound 2.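

Within the data shown here, the ring-nitrogen acyl position responds to a small change: acetyl to propanoyl gives an at least 8.1-fold lower number from compound 2 to compound 4 (0.91 log units; beyond the scatter) in this assay and is the first reading at this position. The earlier compounds shown here offered a measured step only at the aryl substituent of the anilide, so this position had no reading until now. Compound 2 gives only a limit, so the full size of this step stays unknown: the limit of > 70000 nM in this assay, at which 1 of the 4 values shown sits.

The compounds shown do not tell whether a longer chain such as butanoyl would lower the number further, or whether an amine at the end of the acyl chain would keep the gain. They also leave open whether the same change would give a similar step on the methoxy anilide of compound 3.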